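A Bromophenyl Isomer Tested for Liver-Cell Toxicity

This account rests on a few compounds, and the source may have more. Where it says the series, first, only, none or still open, it means among the compounds named here.

Of the compounds shown here, three have so far been measured in an ADME assay on HepG2 cells (Homo sapiens) for cytotoxicity, read by MTT assay, with a stated time of 48 h; on this read-out lower numbers stand for higher toxicity in this test and higher numbers for lower toxicity in this test. Compound 1 `CC(=O)OC[C@H]1O[C@H](OC[C@H](Cn2cc(COc3ccc(-c4noc(NC5CCCCC5)n4)cc3)nn2)OC(C)=O)C=C[C@@H]1OC(C)=O` gives 99.5 ug/mL, compound 2 `C#CCN(c1nc(-c2cccc(Br)c2)no1)C1CCCCC1` gives 53.5 ug/mL, and compound 3 `CC(=O)OC[C@H]1O[C@H](OC[C@@H](Cn2cc(CN(c3nc(-c4ccc(Cl)cc4)no3)C3CCCCC3)nn2)OC(C)=O)C=C[C@@H]1OC(C)=O` gives 46.9 ug/mL. Among these three numbers compound 2 holds the second highest, but its gap to compound 3 and its gap to compound 1 both lie within the usual scatter of this assay, so the three compounds cannot be told apart on these data.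

Compound 4 `C#CCN(c1nc(-c2ccc(Br)cc2)no1)C1CCCCC1` is built from the same atoms as compound 2, joined differently: 4-bromophenyl in place of 3-bromophenyl on an aromatic carbon. Apart from where the bromine substituent sits on the phenyl ring, the two structures are the same.

Within the data shown here, no pair of measured compounds differs in this one place, so there is no measured step to lean on. Given the smallness of the change, the step of a 1.1-fold lower number from compound 2 to compound 4 (0.03 log units; within the scatter) is expected to stay within the scatter, with no clear direction. Compound 4 is therefore estimated at 50 ug/mL, with a range from 25 ug/mL to 100 ug/mL.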

Compound 4, half-maximal cytotoxic concentration: 102 ug/mL
For compound 4 the middle estimate is 2.0-fold (0.31 log units) below the measured one; measured number outside the range, above it.
By their numbers in this assay, from the lowest: compounds 3, 2, 1 and 4 (each within the scatter of the next, the first and the last beyond it).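

In this assay, among these compounds, moving the bromine, so that 4-bromophenyl replaces 3-bromophenyl on an aromatic carbon of the five-membered ring, gives a 1.9-fold higher number from compound 2 to compound 4 (0.28 log units; within the scatter) and provides the first measured step at this position. This step does not show that the bromine's place on the phenyl ring matters, since compound 2 and compound 4 cannot be told apart in this test. No supporting measurement bears on this result, so the data offer no explanation for the numbers.

Going by these compounds, what remains open is whether a different group at this place would give a step beyond the scatter, for example an unsubstituted phenyl, or a phenyl carrying an amine or a carboxylic acid instead of bromine. Repeat measurements of compound 2 and compound 4 would also help to settle whether their numbers truly differ.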